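The compounds below may be only part of what the source reports. "The series", "measured", "known", "first", "only" and "open" are said of these compounds alone.

The measured compounds:

Compound 1 `Cc1nc(C)c(-c2nn(-c3ccc(F)cc3)cc2/C=C/C(=O)c2cc(Cl)cc(Cl)c2O)s1` gives > 250 ug/mL in an ADME assay on PANC-1 cells (Homo sapiens) for inhibition, read by MTT assay; a lower number here means a stronger inhibitor of growth, a higher number a weaker inhibitor of growth.
Compound 2 `Cc1nc(C)c(-c2nn(-c3ccc(F)cc3)cc2/C=C/C(=O)c2c(O)cc(C)c(Cl)c2C)s1` gives 35.2 ug/mL.
Compound 3 `Cc1nc(C)c(-c2nn(-c3ccc(F)cc3)cc2C2CC(c3cc(Br)ccc3O)=NN2)s1` gives 76.4 ug/mL.

The value of compound 1 is a limit of this assay rather than a number. Among the two numbers, compound 3 stands highest, and its nearest neighbour is compound 2, which lies lower by a margin beyond the usual scatter. Among the measured compounds shown here, the only measured step joins those first two compounds: an at least 7.1-fold lower number from compound 1 to compound 2 (0.85 log units; beyond the scatter). That step concerns the ring on the carbonyl carbon, a part of the structure that compound 3 and compound 4 `Cc1nc(C)c(-c2nn(-c3ccc(F)cc3)cc2C2CC(c3cc(Cl)ccc3O)=NN2)s1` do not share, so it does not speak to the change at hand.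

The change from compound 3 to compound 4 is chloro in place of bromo on an aromatic carbon. For the measured compounds named here, no measured pair here differs in that way, so there is nothing to suggest a direction for it, and the expectation is a step within the scatter. The estimate for compound 4 in this assay is therefore 76 ug/mL, with a range from 38 ug/mL to 152 ug/mL, meaning an expected step of a 1.0-fold lower number from compound 3 to compound 4 (0.00 log units; within the scatter) from its neighbour compound 3.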

Compound 4, concentration for 50% growth inhibition: > 250 ug/mL
Compound 4 was reported as a limit; the forecaster's own chance of this, stated with the estimate: 5%; middle value at least 3.2-fold (0.51 log units) away from the limit.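

Exchanging one halogen for another on the aromatic carbon para to a hydroxy group is not a neutral change in this assay: chloro in place of bromo gives an at least 3.2-fold higher number from compound 3 to compound 4 (0.51 log units; beyond the scatter), and a higher number here means a weaker inhibitor of growth. Compound 4 gives > 250 ug/mL, which is a limit of the assay and not a number. The step therefore fixes a direction and a smallest possible size, but its true size remains unknown because the value of compound 4 sits at this assay's limit: the limit of > 250 ug/mL in this assay, at which 2 of the 4 values shown sit.

Bromo and chloro are the only groups compared at this position, so it remains open whether fluoro, methyl or methoxy there would give a number closer to that of the bromo compound or one as high as that of the chloro compound. It is also open whether the same exchange would shift the number in the same direction on compounds with the carbonyl chain, such as compound 1 and compound 2, since no pair shown tests it there.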